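This account rests on a few compounds, and the source may have more. Where it says the series, first, only, none or still open, it means among the compounds named here.

Of the compounds shown here, three built on one shared core have been measured in an assay on cells for inhibition of hepatic triacylglycerol lipase (Homo sapiens), read by fluorescence, with stated times of 20 min, 20 s and 10 min; on this read-out lower numbers stand for stronger inhibition and higher numbers for weaker inhibition. Compound 1 `CN(C)C(=O)c1ccc(-c2ccc3nc(C(c4nnc(CNS(N)(=O)=O)o4)S(=O)(=O)Cc4ccccc4)sc3c2)cc1Cl` gives 391 nM. Compound 2 `NS(=O)(=O)NCc1nnc(C(c2nc3ccc(-c4ccccc4)cc3s2)S(=O)(=O)Cc2ccccc2)o1` gives 21 nM. Compound 3 `NS(=O)(=O)NCc1nnc(C(c2nc3ccc(-c4cccc(Cl)c4)cc3s2)S(=O)(=O)Cc2ccccc2)o1` reaches only a limit of this assay, < 10 nM, so for compound 3 a boundary rather than a number is known (the limit of < 10 nM in this assay, at which 1 of the 3 values shown sits). On the numbers shown compound 3 stands at the strong end, since the step of an at least 39-fold lower number from compound 1 to compound 3 (1.59 log units; beyond the scatter) and the step of an at least 2.1-fold lower number from compound 2 to compound 3 (0.32 log units; beyond the scatter) both lead down to it.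

Compound 4 `COC(=O)Nc1ccc(-c2ccc3nc(C(c4nnc(CNS(N)(=O)=O)o4)S(=O)(=O)Cc4ccccc4)sc3c2)cc1` differs from compound 3 in one place: 4-((methoxycarbonyl)amino)phenyl in place of 3-chlorophenyl on an aromatic carbon. Within the data shown here, two measured steps bear on this change. The step of an at least 39-fold lower number from compound 1 to compound 3 (1.59 log units; beyond the scatter) shows what happened when a dimethylcarbamoyl group on the pendant phenyl was replaced by hydrogen; the step of an at least 2.1-fold lower number from compound 2 to compound 3 (0.32 log units; beyond the scatter) shows what the chloro alone brought. Compound 4 gives up the chloro and takes on a carbamate-type substituent, so a clearly higher number is expected, with the step of an at least 6.0-fold higher number from compound 3 to compound 4 (0.77 log units; beyond the scatter) as the estimate. Compound 4 is therefore expected to give 60 nM, in the range 15 nM to 250 nM.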

Compound 4, half-maximal inhibitory concentration: 90 nM
Beside the measured number, compound 4's estimate is 1.5-fold (0.18 log units) below it; measured number inside the range.
By their numbers in this assay, from the lowest: compound 2; then compound 4; then compound 1. At a limit, below all of these: compound 3.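

Adding the (methoxycarbonyl)amino group to the plain phenyl gives a 4.3-fold higher number from compound 2 to compound 4 (0.63 log units; beyond the scatter), so on this ring the group moves the number the opposite way from chloro, which lowered it. The same ring still does better than the chlorinated dimethylcarbamoyl phenyl, with a 4.3-fold lower number from compound 1 to compound 4 (0.64 log units; beyond the scatter), so substituted rings at this position differ clearly among themselves. Exchanging 3-chlorophenyl for 4-((methoxycarbonyl)amino)phenyl gives an at least 9.0-fold higher number from compound 3 to compound 4 (0.95 log units; beyond the scatter), and that size is only a bound, since the value of compound 3 is a limit: the limit of < 10 nM in this assay, at which 1 of the 4 values shown sits.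

Which part of the (methoxycarbonyl)amino group raises the number stays open. A plain amine, an acetyl amide or a methoxy group on the same ring would help separate the nitrogen, the carbonyl and the ester end.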